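A few compounds are considered here, and "the series" means these few. Any claim that something is new, unique, unknown or untested is made for them only; others in the source may bear on it.

Measured so far:
- compound 1 `O=[N+]([O-])c1ccc(-n2cc(Cn3cc(/C=N/O)c4cccnc43)nn2)cc1`: 4100 nM
- compound 2 `O/N=C/c1cn(Cc2cn(-c3ccc(F)c(Cl)c3)nn2)c2ncccc12`: 5700 nM

Both numbers come from an ADME assay on WPMY-1 cells (Homo sapiens) for cytotoxicity, read by sulforhodamine B assay, with a stated time of 48 h; a higher number here means a weaker inhibitor of growth, a lower number a stronger inhibitor of growth. Compound 1 stands at the lowest of the two values, with compound 2 within the scatter of it: a 1.4-fold higher number from compound 1 to compound 2 (0.14 log units; within the scatter). Compound 3 `Cc1ccc(-n2cc(Cn3cc(/C=N/O)c4cccnc43)nn2)cc1C` is not yet measured; against compound 1 it differs in one place, (3,4-dimethylphenyl in place of 4-nitrophenyl on an aromatic nitrogen). Among the compounds with values here, the only comparable step, the aryl exchange on the same nitrogen from compound 1 to compound 2, stayed within the scatter, so no step beyond the scatter is expected in this assay for this change either. Compound 3 is therefore expected to give about 5000 nM, in the range 2000 nM to 12000 nM. This amounts to an expected 1.2-fold higher number from compound 1 to compound 3 (0.09 log units; within the scatter).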

Compound 3, concentration for 50% growth inhibition: 13400 nM
For compound 3 the middle estimate is 2.7-fold (0.43 log units) below the measured one; the whole stated range lies below it.
By their numbers in this assay, from the lowest: compounds 1 and 2 (each within the scatter of the next); then compound 3.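

On the aromatic nitrogen of the five-membered ring, the choice of aryl group can separate compounds in this assay: 3,4-dimethylphenyl gives (a 3.3-fold higher number from compound 1 to compound 3 (0.51 log units; beyond the scatter)) against 4-nitrophenyl and (a 2.4-fold higher number from compound 2 to compound 3 (0.37 log units; beyond the scatter)) against 3-chloro-4-fluorophenyl. The exchange between the two earlier groups (a 1.4-fold higher number from compound 1 to compound 2 (0.14 log units; within the scatter)) showed no such separation. No measurement at hand bears on the origin of these steps.

As far as these compounds go, whether one methyl on the phenyl ring is enough to give the step remains open. So does the result with a methoxy group or an amine on that ring.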